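The compounds below may be only part of what the source reports. "The series", "measured", "known", "first", "only" and "open" are said of these compounds alone.

Measured compounds so far:
compound 1 `CN(C)CCn1cnnc1-c1cc(Oc2ccc(NC(=O)N/N=C/c3cc(C(C)(C)C)cc(C(C)(C)C)c3O)cc2F)ccn1` — 3300 nM
compound 2 `COc1cc(/C=N/NC(=O)Nc2ccc(Oc3ccnc(-c4nncn4CCN(C)C)c3)c(F)c2)cc(OC)c1OC` — 2900 nM

Both numbers come from a functional assay on MKN-45 cells (Homo sapiens) for cytotoxicity, read by MTT assay, with a stated time of 72 h; a lower number here means a stronger inhibitor, a higher number a weaker inhibitor. In this assay compound 1 gives 3300 nM and compound 2 gives 2900 nM. Compound 2 stands level with compound 1: the gap between their numbers lies within the scatter, so the two cannot be separated on what is measured. Within the data shown here, no single-point step between measured compounds is available, and the two compounds differ at several places at once.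

Compound 3 `COc1cc(/C=N/NC(=O)Nc2ccc(Oc3ccnc(-c4nncn4CCN(C)C)c3)c(F)c2)ccc1O` is not yet measured. It differs from compound 2 in one place: 4-hydroxy-3-methoxyphenyl in place of 3,4,5-trimethoxyphenyl on a carbon with a double bond to nitrogen. Neither measured value speaks to this particular change, so the expectation rests only on the narrow spread seen so far between compound 1 and compound 2. In this assay the expected change is a 1.2-fold higher number from compound 2 to compound 3 (0.08 log units; within the scatter), with no direction beyond the scatter favoured. Compound 3 is estimated at 3500 nM, with a range from 1400 nM to 9000 nM.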

Compound 3, half-maximal inhibitory concentration: 3780 nM
Compound 3: the middle estimate sits 1.1-fold (0.03 log units) below what was measured, and the stated range covers the measured number.
By their numbers in this assay, from the lowest: compounds 2, 1 and 3 (each within the scatter of the next).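

At the position on a carbon with a double bond to nitrogen, the series now has its first comparison that differs in one place: in this assay, 4-hydroxy-3-methoxyphenyl in place of 3,4,5-trimethoxyphenyl gives a 1.3-fold higher number from compound 2 to compound 3 (0.12 log units; within the scatter). The entering group carries a hydrogen-bond donor that the leaving group lacks and has fewer heavy atoms, yet this exchange does not separate compound 2 from compound 3 on this read-out. No measurement on hand accounts for this result.

Still open, as far as these compounds go, is whether an unsubstituted phenyl, or a phenyl carrying an amine or a carboxylic acid, at this position would give a step beyond the scatter. Also open, from the compounds shown here alone, is whether a change to the shared core, with this group held fixed, would move the number in this assay beyond the scatter.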